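Isopropoxy in Place of Dimethylamino: An Expected Growth-Inhibition Value

The source may report more compounds than this note shows. Statements on the series, on what has been measured and on what is new or still open speak of the compounds shown alone.

Of the compounds shown here, three have been measured in a functional assay on MV4-11 cells (Homo sapiens) for inhibition, read by resazurin assay, with a stated time of 72 h; on this read-out lower numbers stand for stronger inhibition of growth and higher numbers for weaker inhibition of growth. Compound 1 `CCn1cc(-c2ccnc(Nc3ccc(OC)cc3OC)n2)c2ccccc21` gives 3590 nM and compound 2 `COc1ccc(Nc2nccc(-c3cn(C)c4ccccc34)n2)c(OC)c1` gives 3410 nM; the step of a 1.1-fold lower number from compound 1 to compound 2 (0.02 log units; within the scatter) lies within the scatter. Compound 3 `COc1ccc(Nc2nccc(-c3sc(N(C)C)nc3C)n2)c(OC)c1` gives 170 nM, the lowest of the three numbers, and it stands far apart from both compound 1 and compound 2.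

Compound 4 `COc1ccc(Nc2nccc(-c3sc(OC(C)C)nc3C)n2)c(OC)c1` has not yet been measured. It differs from compound 3 in a single place: isopropoxy in place of dimethylamino on an aromatic carbon. Within the data shown here, the only measured step, from compound 1 to compound 2, concerns a methyl on a saturated chain carbon of a different core and gives no guidance on exchanging one group for another on the five-membered aromatic ring. Among the measured compounds shown here, with no measured step bearing on the change, the expectation rests on compound 3 alone, and the expected step of a 1.8-fold higher number from compound 3 to compound 4 (0.25 log units; within the scatter) is a modest weakening with a wide range. Compound 4 is expected to give 300 nM, estimated to lie between 100 nM and 900 nM.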

Compound 4, concentration for 50% growth inhibition: 8690 nM
For compound 4 the middle estimate is 29-fold (1.46 log units) below the measured one, and the stated range ends below it.
By their numbers in this assay, from the lowest: compound 3; then compounds 2 and 1 (each within the scatter of the next); then compound 4.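

In this assay, this place on the five-membered aromatic ring, next to the ring nitrogen and next to the ring sulfur, proves highly sensitive to the group it carries: isopropoxy in place of dimethylamino gives a 51-fold higher number from compound 3 to compound 4 (1.71 log units; beyond the scatter). The counts do not separate the two groups well, since each has no ring, 0 hydrogen-bond donors, 1 hydrogen-bond acceptor and no net charge, and they differ only slightly in size, at 3 and 4 heavy atoms. Nothing measured here explains why this exchange matters so much.

The exchange alters both the atom bound to the ring and the shape of the group, so the compounds shown cannot tell these two changes apart. A diethylamino or an ethoxy group at this place could help separate them, showing whether the nitrogen or the branched chain counts more.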